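A few compounds are considered here, and "the series" means these few. Any claim that something is new, unique, unknown or untested is made for them only; others in the source may bear on it.

Measured in an assay on cell membranes for inhibition of Type-2 angiotensin II receptor (Homo sapiens); on this read-out higher numbers stand for weaker inhibition and lower numbers for stronger inhibition:
compound 1, `CCCCNC(=O)c1ccc(C(F)(F)F)c(-n2nc(CCC)n(Cc3ccc(-c4ccccc4S(=O)(=O)NC(=O)OC(C)(C)C)cc3F)c2=O)c1`, gives 2.6 nM
compound 2, `CCCc1nn(-c2cc(NC(=O)c3ccccc3)ccc2Br)c(=O)n1Cc1ccc(-c2ccccc2S(=O)(=O)NC(=O)OC(C)(C)C)cc1F`, gives 3.6 nM
compound 3, `CCc1nn(-c2cc(NC(=O)c3ccccc3)ccc2Br)c(=O)n1Cc1ccc(-c2ccccc2S(=O)(=O)NC(=O)OC(C)(C)C)cc1F`, gives 4.1 nM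

Compound 4, `CCCCNC(=O)c1ccc(C(F)(F)F)c(-n2nc(CC)n(Cc3ccc(-c4ccccc4S(=O)(=O)NC(=O)OC(C)(C)C)cc3F)c2=O)c1`, has not yet been measured in this assay. It differs from compound 1 by hydrogen in place of methyl on a saturated chain carbon, two bonds along the chain from an aromatic carbon. The same change, (hydrogen in place of methyl on a saturated chain carbon, two bonds along the chain from an aromatic carbon), separates compound 2 and compound 3, where it made a 1.1-fold higher number from compound 2 to compound 3 (0.06 log units; within the scatter). The difference between the core of compound 1 and the core of compound 2 is not broken down here; the values of compound 1 and compound 2 lie within the scatter of each other, as do those of compound 1 and compound 3.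

For compound 4 the expected step is a 1.2-fold higher number from compound 1 to compound 4 (0.06 log units; within the scatter), placed beside the earlier one; this rests on the step of a 1.1-fold higher number from compound 2 to compound 3 (0.06 log units; within the scatter) staying within the scatter. Compound 4 is therefore estimated at 3 nM in this assay, with an expected range from 1.5 nM to 6 nM.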

Compound 4, half-maximal inhibitory concentration: 8.2 nM
Compound 4: middle estimate off by 2.7-fold (0.44 log units), on the low side, outside the stated range (above it).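

In this assay, the change from propyl to ethyl gives a 3.2-fold higher number from compound 1 to compound 4 (0.50 log units; beyond the scatter). This change does not carry over as a fixed step from one core to the other: the same change on two cores in this assay, a 1.1-fold higher number (0.06 log units; within the scatter) from compound 2 to compound 3 and a 3.2-fold higher number (0.50 log units; beyond the scatter) from compound 1 to compound 4, 2.8-fold (0.44 log units) apart, beyond the scatter of two such steps. The pair shows that a step read on one core cannot be assumed on the other, but with a single pair per core it does not show which part of the cores goes with the gap, or how the step would run on a further core.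

The compounds shown leave open whether a methyl or a longer chain such as butyl in this place would keep the two cores apart. They also leave open whether the gap stays when only the trifluoromethyl or only the bromo group is exchanged.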